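From fluoro to 4-aminophenyl on a shared core

The compounds below may be only part of what the source reports. "The series", "measured", "known", "first", "only" and "open" are said of these compounds alone.

Three compounds sharing one core were tested in a functional assay on KYSE-410 cells (Homo sapiens) for antiproliferative activity, read by MTT assay, with a stated time of 72 h; a higher number here means a weaker inhibitor, a lower number a stronger inhibitor. Compound 1 `O=C(Nc1ccc(OC(F)(F)F)cc1)c1cc(=O)[nH]c2cc(Br)ccc12` gives only a limit in this assay, > 20000 nM. Compound 2 `O=C(Nc1cc(F)c(F)c(F)c1)c1cc(=O)[nH]c2cc(Br)ccc12` likewise gives only a limit, > 20000 nM. Compound 3 `O=C(Nc1cccc(F)c1)c1cc(=O)[nH]c2cc(F)ccc12` also gives only a limit, > 20000 nM. Compound 3 therefore stands exactly where the other two measured compounds stand: none of the three reached a numerical value, as the limit of > 20000 nM in this assay, at which 3 of the 3 values shown sit, shows, and nothing in these numbers separates compound 3 from compound 1 or compound 2. Within the data shown here, no pair of measured compounds that differ in a single place is available, so no measured step can be read from the data.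

Compound 4 `Nc1ccc(-c2ccc3c(C(=O)Nc4cccc(F)c4)cc(=O)[nH]c3c2)cc1` is the compound not yet measured. It differs from compound 3 by 4-aminophenyl in place of fluoro on an aromatic carbon. Among the measured compounds shown here, with compound 3 sitting at a limit and no measured step to lean on, the direction and size of this change cannot be taken from the data; the expectation is that compound 4 moves toward stronger inhibition in this assay, though a move within the scatter, or none at all, remains possible. The expected step is an at least 3.3-fold lower number from compound 3 to compound 4 (0.52 log units; beyond the scatter). Compound 4 is expected to give 6000 nM in this assay, with a likely range from 800 nM to 20000 nM.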

Compound 4, half-maximal inhibitory concentration: > 20000 nM
Compound 4 ended at the assay's limit (the forecaster's own chance of this, stated with the estimate: 35%); at least 3.3-fold (0.52 log units) between middle value and limit.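

Compound 3 and compound 4 both end at a limit and not at a number, so no step can be read between them, and all the compounds shown sit at the same point: the limit of > 20000 nM in this assay, at which 4 of the 4 values shown sit.

Which change to the shared core, if any, would give a numerical value in this assay remains open.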